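A few compounds are considered here, and "the series" means these few. Any claim that something is new, unique, unknown or untested is made for them only; others in the source may bear on it.

Within the data shown here, in a physicochemical assay for lipophilicity (a lower number here means a more polar compound, a higher number a more lipophilic compound), compound 1 `COc1ccc(C2C[C@@]3(ON2c2ccccc2)C(=O)O[C@@H]2[C@H]3CC[C@H](C)[C@]3(O)C=CC(=O)[C@@]23C)cc1Br` gives 3.98 and compound 2 `C[C@H]1CC[C@@H]2[C@@H](OC(=O)[C@]23CC(c2ccccc2Cl)N(c2ccccc2)O3)[C@]2(C)C(=O)C=C[C@@]12O` gives 3.87, so compound 2 stands level with its only measured neighbour. Compound 3 `C[C@H]1CC[C@@H]2[C@@H](OC(=O)[C@]23CC(c2ccc([N+](=O)[O-])cc2)N(c2ccccc2)O3)[C@]2(C)C(=O)C=C[C@@]12O` has 4-nitrophenyl in place of 2-chlorophenyl on a saturated ring carbon, next to the ring nitrogen: 4-nitrophenyl in place of 2-chlorophenyl on a saturated ring carbon. Among the measured compounds shown here, the one measured step that bears on this, a number 0.11 log units lower from compound 1 to compound 2 (within the scatter), exchanged groups on that same carbon, but neither of them was 4-nitrophenyl, so it is only a loose guide. A modest fall in this assay is expected, a number 0.27 log units lower from compound 2 to compound 3 (within the scatter). The estimate for compound 3 is 3.6, with an expected range of 3.2 to 3.95.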

Compound 3, partition coefficient: 3.15
Compound 3: middle estimate off by 0.45 log units, on the high side; the whole stated range lies above it.
By their numbers in this assay, from the lowest: compound 3; then compounds 2 and 1 (each within the scatter of the next).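

At the saturated ring carbon next to the ring nitrogen, this assay now shows a change beyond the scatter: 4-nitrophenyl gives a number 0.72 log units lower from compound 2 to compound 3 (beyond the scatter) and a number 0.83 log units lower from compound 1 to compound 3 (beyond the scatter) in this series. The exchange of aryl groups on this carbon is therefore not always silent, and compound 3 stands apart from the other two compounds. Nothing available gives a reason for the size of these steps.

On these data alone, it remains open whether a 4-aminophenyl or 4-carboxyphenyl group on this carbon would stand with compound 3 or with the other two compounds.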